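Fluorine pattern on the benzyl group and cell tolerance

This account rests on a few compounds, and the source may have more. Where it says the series, first, only, none or still open, it means among the compounds named here.

Measured so far in an ADME assay on MT4 cells (Homo sapiens) for cytotoxicity, read by MTT assay; a higher number here means that more compound is tolerated, a lower number that less compound is tolerated:
compound 1 `CCOC(=O)/C(O)=C/C(=O)c1cn(Cc2cc(F)c(F)c(F)c2)c2cccc(OC)c12` gives 33400 nM
compound 2 `COc1cccc2c1c(C(=O)/C=C(\O)C(=O)O)cn2Cc1cccc(F)c1F` gives 17500 nM
compound 3 `CCOC(=O)/C(O)=C/C(=O)c1cn(Cc2cccc(F)c2F)c2cccc(OC)c12` gives 21100 nM

Compound 3 holds the second highest of the three numbers, but none of the three separates from another: the step of a 1.2-fold higher number from compound 2 to compound 3 (0.08 log units; within the scatter) is within the scatter, and so is a 1.6-fold lower number from compound 1 to compound 3 (0.20 log units; within the scatter). On this assay compound 3 therefore stands among values that cannot be ordered.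

Compound 4 `CCOC(=O)/C(O)=C/C(=O)c1cn(Cc2c(F)ccc(F)c2F)c2cccc(OC)c12` differs from compound 3 by fluoro in place of hydrogen on an aromatic carbon, on an aromatic carbon of a six-membered aromatic ring of carbon only, ortho to a large group, meta to a fluoro group and para to a fluoro group; read one bond further out, 2,3-difluorobenzyl becomes 2,3,6-trifluorobenzyl.

For the measured compounds named here, only one measured step changes the fluorine pattern on this ring, a 1.6-fold lower number from compound 1 to compound 3 (0.20 log units; within the scatter), and it stays within the scatter. The step of a 1.2-fold higher number from compound 2 to compound 3 (0.08 log units; within the scatter) concerns the ester and does not bear on the change. No step beyond the scatter is therefore expected here, estimated as a 1.0-fold lower number from compound 3 to compound 4 (0.00 log units; within the scatter). Compound 4 is expected at 21000 nM, with a range from 10000 nM to 42000 nM.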

Compound 4, half-maximal cytotoxic concentration: 40500 nM
For compound 4 the middle estimate is 1.9-fold (0.29 log units) below the measured one, within the range that was stated.
By their numbers in this assay, from the lowest: compounds 2, 3, 1 and 4 (each within the scatter of the next, the first and the last beyond it).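

In this assay, a third fluoro group on the ring, turning 2,3-difluorobenzyl into 2,3,6-trifluorobenzyl, gives a 1.9-fold higher number from compound 3 to compound 4 (0.28 log units; within the scatter) and so stays inside the scatter, which means this place, ortho to a large group, takes fluoro without a difference that can be read. For the compounds shown here, the two trifluorobenzyl patterns cannot be told apart either, with a 1.2-fold higher number from compound 1 to compound 4 (0.08 log units; within the scatter) as the only comparison between them. No measurement at hand speaks to why these numbers fall where they do.

Open, on these data alone, is whether a chloro group or an amine at this same place would also stay within the scatter of compound 3. Also open, as far as these compounds go, is whether the 2,3,6-trifluorobenzyl group would hold its number with a carboxylic acid in place of the ethyl ester.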